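A few compounds are considered here, and "the series" means these few. Any claim that something is new, unique, unknown or untested is made for them only; others in the source may bear on it.

In an ADME assay on the whole organism with Oryza sativa as the target, tested at 1 uM; a lower number here means a stronger effect, a higher number a weaker effect of the compound at the concentration tested:
compound 1 `C[C@H](NC(=O)Nc1ccccc1F)c1ccccc1`: 92%
compound 2 `C[C@H](NC(=O)Nc1ccc(F)cc1F)c1ccccc1`: 100%

Compound 2 sits together with compound 1; the gap between them is a number 8 percentage points higher from compound 1 to compound 2 (within the scatter), so the two are not separable on these numbers. Compound 3 `Cc1cc(F)ccc1NC(=O)N[C@@H](C)c1ccccc1` is the next step from compound 2, (methyl in place of fluoro on an aromatic carbon). Among the measured compounds shown here, the only measured step, a number 8 percentage points higher from compound 1 to compound 2 (within the scatter), came with fluoro in place of hydrogen on an aromatic carbon, a different exchange, and no measured step swaps methyl for fluoro, so no move beyond the scatter is expected here. Compound 3 is therefore expected near 95%, range 80% to 100%, a step of a number 5 percentage points lower from compound 2 to compound 3 (within the scatter).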

Compound 3, a percentage reported as activity, at one concentration (the size of the read-out at that concentration, not a potency): 98%
Estimate against measurement, compound 3: 3 percentage points below; measured number inside the range.
By their numbers in this assay, from the lowest: compounds 1, 3 and 2 (each within the scatter of the next).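

In this assay, methyl in place of fluoro, on the aromatic carbon ortho to a large group and meta to a fluoro group, gives a number 2 percentage points lower from compound 2 to compound 3 (within the scatter), so the two compounds are not separable on this read-out. Among the compounds shown here, this position, until now seen only with fluoro, also accepts methyl without a separable change. Nothing on hand gives a reason for this result.

As far as these compounds go, whether an amine, a carboxylic acid or a longer chain at this position would move the number beyond the scatter stays open. So does the outcome of a methoxy group in place of the remaining fluoro group.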